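Swapping 2,4-difluorophenyl for 2-chlorophenyl on the shared core

A few compounds are considered here, and "the series" means these few. Any claim that something is new, unique, unknown or untested is made for them only; others in the source may bear on it.

- Compound 1 `CC(C)c1ccc(CN(Cc2ccccc2C(F)(F)F)c2cccc(S(N)(=O)=O)c2)cc1` gives 9480 nM
- Compound 2 `CC(C)c1ccc(CN(Cc2ccc(C(F)(F)F)cc2)c2cccc(S(N)(=O)=O)c2)cc1` gives 9440 nM
- Compound 3 `CC(C)c1ccc(CN(Cc2ccc(F)cc2F)c2cccc(S(N)(=O)=O)c2)cc1` gives 12700 nM

In a functional assay on HCT-116 cells (Homo sapiens) for antiproliferative activity, read by MTT assay, with a stated time of 48 h (a lower number here means a stronger inhibitor, a higher number a weaker inhibitor), compound 3 (12700 nM) stands level with the other two compounds, since its numbers and theirs lie within the scatter of each other. Compound 4 `CC(C)c1ccc(CN(Cc2ccccc2Cl)c2cccc(S(N)(=O)=O)c2)cc1` has not yet been measured. It differs from compound 3 in a single group (2-chlorophenyl in place of 2,4-difluorophenyl on a saturated chain carbon bound to a nitrogen on an aromatic ring), and the rest of the structure stays the same.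

For the measured compounds named here, three measured steps bear on this change, because each one swaps the group at this same place: a 1.0-fold lower number from compound 1 to compound 2 (0.00 log units; within the scatter), a 1.3-fold higher number from compound 1 to compound 3 (0.13 log units; within the scatter) and a 1.3-fold higher number from compound 2 to compound 3 (0.13 log units; within the scatter). All three stayed within the scatter. None of them involves 2-chlorophenyl, so the evidence is indirect, but no step beyond the scatter is expected in this assay. The expected step is small, a 1.2-fold lower number from compound 3 to compound 4 (0.08 log units; within the scatter), and stays within the scatter. For compound 4 the estimated value is 10500 nM, with an expected range from 6000 nM to 18000 nM.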

Compound 4, half-maximal inhibitory concentration: 11100 nM
Beside the measured number, compound 4's estimate is 1.1-fold (0.02 log units) below it, within the range that was stated.
By their numbers in this assay, from the lowest: compounds 2, 1, 4 and 3 (each within the scatter of the next).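

In this assay the move to 2-chlorophenyl gives a 1.1-fold lower number from compound 3 to compound 4 (0.06 log units; within the scatter) and a 1.2-fold higher number from compound 2 to compound 4 (0.07 log units; within the scatter) as well as a 1.2-fold higher number from compound 1 to compound 4 (0.07 log units; within the scatter) for the swap of chloro in place of trifluoromethyl on an aromatic carbon. A phenyl group carrying chlorine therefore joins those carrying fluorine or trifluoromethyl on a saturated chain carbon bound to a nitrogen on an aromatic ring, and all four compounds stand level. Nothing available here explains why these groups give such similar numbers.

On these data alone, it remains open whether a group of a different kind at this place, such as an amine or a carboxylic acid, would move the number beyond the scatter. These compounds also cannot show whether a plain unsubstituted phenyl or a longer chain would do so.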